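This account rests on a few compounds, and the source may have more. Where it says the series, first, only, none or still open, it means among the compounds named here.

For the measured compounds named here, compound 2 `O=C1NC(=S)S/C1=C\C=C\c1ccccc1OCc1ccccc1` gives 65% in a functional assay on DLD-1 cells (Homo sapiens), read by microscopy and crystal violet staining, with a stated time of 20 h, tested at 10 ug/mL (on this read-out higher numbers stand for more inhibition at the one concentration tested (going by the name of the read-out) and lower numbers for less inhibition), the lower of the two numbers measured so far; compound 1 `COc1ccccc1COc1ccccc1/C=C/C=C1\SC(=S)NC1=O` gives 98% in this assay. Going by the values given here, the one measured step, a number 33 percentage points lower from compound 1 to compound 2 (beyond the scatter), concerns a methoxy on a different ring and does not bear directly on the change to compound 3 `Cc1ccccc1COc1ccccc1/C=C/C=C1\SC(=S)NC1=O`, which is methyl in place of hydrogen on an aromatic carbon. Among the compounds with values here, no measured step guides this change, so the account expects no step beyond the scatter, no change at the digits printed from compound 2 to compound 3 (within the scatter). Compound 3 is therefore estimated at 65%, in a range from 35% to 90%.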

Compound 3, a percentage reported as inhibition, at one concentration (the size of the read-out at that concentration, not a potency): 73%
The estimate for compound 3 lay 8 percentage points below the measured number; the range from low to high includes it.
By their numbers in this assay, from the lowest: compounds 2 and 3 (each within the scatter of the next); then compound 1.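

In this assay, methyl in place of hydrogen on this aromatic carbon, ortho to a large group, gives a number 8 percentage points higher from compound 2 to compound 3 (within the scatter), so the two groups cannot be told apart here. Methyl in place of methoxy gives a number 25 percentage points lower from compound 1 to compound 3 (beyond the scatter), which shows that a one-carbon group alone does not match compound 1 and leaves methoxy with the highest number of the three. Nothing available explains this difference. Open, as far as these compounds go, is where ethoxy, hydroxyl or chlorine at this place would fall relative to compound 1 and compound 3. Also open, from the compounds shown here alone, is whether methoxy would keep its number on another carbon of this ring.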